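Compound 3 to compound 4: tolerance near the limit

The source may hold more compounds than are shown below. What is called first, only, known or untested is meant among the compounds shown, and "the series" means these compounds.

In an ADME assay on MDCK cells (Canis lupus familiaris) for cytotoxicity, read by MTT assay, with a stated time of 2 days (a lower number here means that less compound is tolerated, a higher number that more compound is tolerated), compound 3 `NCCCc1ccc(-c2ccc(-c3ccc(CCCN)s3)s2)s1` gives > 200000 nM, which is a limit of the assay and not a number. Compound 1 `[N-]=[N+]=NCCCc1ccc(-c2ccc(-c3ccc(-c4cccs4)s3)s2)s1` gives > 100000 nM, also a limit. For compound 2 `NCCCCc1ccc(-c2ccc(-c3ccc(-c4cccs4)s3)s2)s1` the entry reads "not determined" (no result reported). Compound 3 therefore cannot be ranked against the others, as this assay has yet to yield a single number in this series.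

The next compound is compound 4 `NCCCc1ccc(-c2ccc(-c3ccc(-c4cccs4)s3)s2)s1`, with thiophen-2-yl in place of 3-aminopropyl on an aromatic carbon. Going by the values given here, no measured step sizes this change, so any expectation is a judgement. The core of compound 4 also stands in compound 1, whose limit of > 100000 nM argues against a drastic drop. A moderate move towards lower numbers is expected, with an at least 3.3-fold lower number from compound 3 to compound 4 (0.52 log units; beyond the scatter) as the estimated step, and a further limit reading would not surprise. Compound 4 is estimated at 60000 nM, with an expected range of 15000 nM to 200000 nM.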

Compound 4, half-maximal cytotoxic concentration: > 200000 nM
Compound 4 was reported as a limit; the forecaster's own chance of this, stated with the estimate: 40%; middle value at least 3.3-fold (0.52 log units) away from the limit.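

Going by these compounds alone, compound 1, compound 3 and compound 4 all stand at limits in this assay, and no step from compound 3 or compound 1 to compound 4 can be read. The compounds shown leave open at what concentration any of them reaches the half-maximal cytotoxic effect.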